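A few compounds are considered here, and "the series" means these few. Any claim that something is new, unique, unknown or untested is made for them only; others in the source may bear on it.

Compound 1 `C[C@@H](c1ccccc1)n1cnc2c(N(C)C)ncnc21`: 33%
Compound 2 `c1ccc(Cn2cnc3cncnc32)cc1`: 33%

In a functional assay on the whole organism for inhibition, with Rattus norvegicus as the target, in the maximal electroshock model, at a dose of 25 mg/kg by the intraperitoneal route (a higher number here means more inhibition at the dose given (going by the name of the read-out), a lower number less inhibition), compound 1 gives 33%, and compound 2 gives 33%, level with compound 1 at the digits shown, a gap within the usual scatter. Compound 3 `CC(C)N(C)c1ncnc2c1ncn2Cc1ccccc1` differs from compound 2 in one place: isopropyl(methyl)amino in place of hydrogen on an aromatic carbon. Within the data shown here, no pair of measured compounds that differ in one place is available, so the size of this step is unknown. Compound 1, with a differently substituted core, stands where compound 2 does, which suggests only a modest step. Compound 3 is therefore expected to give 35%, with a range from 15% to 60%, an expected step of a number 2 percentage points higher from compound 2 to compound 3 (within the scatter) hardly beyond the scatter.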

Compound 3, a percentage reported as inhibition, in the whole organism at one dose (the size of the read-out at that dose, not a potency): 17%
Beside the measured number, compound 3's estimate is 18 percentage points above it, within the range that was stated.
By their numbers in this assay, from the lowest: compound 3; then compounds 1 and 2 (each within the scatter of the next).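

In this assay, isopropyl(methyl)amino in place of hydrogen on this aromatic carbon gives a number 16 percentage points lower from compound 2 to compound 3 (beyond the scatter). This first readable step at the position shows that what sits here can matter: this group goes with less inhibition at the dose given, not more. Nothing measured here explains the drop.

From the compounds shown here alone, whether any group on this carbon would lower the number, or only this one, stays open. A simple amino group or a chlorine atom in the same place would help separate those two possibilities.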